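Chloro to Bromo: Expected Half-Life of Compound 3

The source may report more compounds than this note shows. Statements on the series, on what has been measured and on what is new or still open speak of the compounds shown alone.

Measured in a physicochemical assay for pharmacokinetics, read by HPLC, at pH 7.5, tested at 250 uM; on this read-out higher numbers stand for a longer-lived compound and lower numbers for a shorter-lived compound:
- compound 1 `Cc1ccc2c(c1)CC(CN(C)C)C2=O`: 0.4 h
- compound 2 `CN(C)CC1Cc2cc(Cl)ccc2C1=O`: 0.117 h

Of these two compounds, compound 2 has the lower number, at 0.117 h. Compound 3 `CN(C)CC1Cc2cc(Br)ccc2C1=O` has not yet been measured. It differs from compound 2 by bromo in place of chloro on an aromatic carbon, with bromo in place of chloro on an aromatic carbon, para to a fused ring.

Going by the values given here, only one measured step bears on this change: a 3.4-fold lower number from compound 1 to compound 2 (0.53 log units; beyond the scatter). Among the compounds with values here, that modest step exchanged methyl for chloro at the same place, so it is only indirect evidence, and no measured compound carries bromo. With this little to go on, no step beyond the scatter is expected in this assay, and no direction is favoured. The estimate means a 1.1-fold lower number from compound 2 to compound 3 (0.03 log units; within the scatter). Compound 3 is expected to give 0.11 h, with an estimated range of 0.06 h to 0.23 h.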

Compound 3, half-life: 0.1 h
Estimate against measurement, compound 3: 1.1-fold (0.04 log units) above, and the stated range covers the measured number.
By their numbers in this assay, from the lowest: compounds 3 and 2 (each within the scatter of the next); then compound 1.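

In this assay, this aromatic carbon now has a direct comparison of one halogen with another, and a 1.2-fold lower number from compound 2 to compound 3 (0.07 log units; within the scatter) lies within the scatter, so chloro and bromo cannot be told apart here. Against methyl, bromo gives the same picture as chloro, since a 4.0-fold lower number from compound 1 to compound 3 (0.60 log units; beyond the scatter) lies beyond the scatter. Among these three compounds, compound 1 with its methyl therefore stands apart from compound 2 and compound 3, and none of the three goes against this.

Going by these compounds, whether fluoro would fall with chloro and bromo remains open, as does where a methoxy group or an amine on this aromatic carbon would fall relative to methyl and the halogens. Nothing measured here accounts for the gap between compound 1 and the two halogen compounds.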